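A few compounds are considered here, and "the series" means these few. Any claim that something is new, unique, unknown or untested is made for them only; others in the source may bear on it.

Compound 1 `COc1c(Br)cc(Br)cc1C(=O)Nc1ccc(Sc2nc3ccccc3s2)c(Cl)c1` in an assay on isolated protein for inhibition of thiosulfate sulfurtransferase (Homo sapiens), with a stated time of 60 min, in the absence of a further agent; a lower number here means a stronger inhibitor, a higher number a weaker inhibitor: > 100000 nM.
Compound 2 `COc1c(Br)cccc1C(=O)Nc1ccc(Sc2nc3ccccc3s2)c(Cl)c1` in this assay: > 100000 nM.

In this assay compound 1 gives > 100000 nM, which is a limit of the assay and not a number. Compound 2 in this assay likewise gives > 100000 nM, again only a limit. The step that the two limits leave unreadable from compound 1 to compound 2 cannot be sized because of the limit of > 100000 nM in this assay, at which 2 of the 2 values shown sit. Compound 2 thus stands at the limit, with no measured number to place it.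

Compound 3 `COc1ccc(Br)cc1C(=O)Nc1ccc(Sc2nc3ccccc3s2)c(Cl)c1` is not yet measured. It differs from compound 2 by a group of 9 heavy atoms (7 carbon, 1 oxygen, 1 bromine; one six-membered aromatic ring of carbon only) in place of a group of 9 heavy atoms (7 carbon, 1 oxygen, 1 bromine; one six-membered aromatic ring of carbon only), on a carbonyl carbon. For the measured compounds named here, the only measured step that bears on this change is the one from compound 1 to compound 2, and its size is unreadable. Nothing in the measured compounds points to a change beyond the scatter, and a further limit is the most likely outcome. The expected step is a step that the limit leaves unreadable from compound 2 to compound 3, within the usual scatter. For compound 3 the estimate in this assay is 150000 nM, with a range from 60000 nM to 500000 nM.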

Compound 3, half-maximal inhibitory concentration: > 100000 nM
Compound 3 was reported as a limit (the forecaster's own chance of this, stated with the estimate: 85%); the middle value is on the limit's open side.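

In this assay compound 3 gives > 100000 nM as a limit of the assay and not a number. Its steps from compound 1 and compound 2 therefore cannot be read: the limit of > 100000 nM in this assay, at which 3 of the 3 values shown sit. The compounds shown leave open what number any of the three would reach in this assay and whether the bromo substitution changes it.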